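Trimethoxyphenyl variant of compound 3: expected behaviour

The source may hold more compounds than are shown below. What is called first, only, known or untested is meant among the compounds shown, and "the series" means these compounds.

Three measured compounds share one core and differ only in the group on a saturated ring carbon. In a functional assay on COLO 205 cells (Homo sapiens) for antiproliferative activity, with a stated time of 48 h (a lower number here means that less compound is tolerated, a higher number that more compound is tolerated), compound 1 `Cc1cc(O)c(C2=NN(c3ccc(S(N)(=O)=O)cc3)C(c3ccccc3O)C2)cc1Cl` gives 6430 nM. Compound 2 `Cc1cc(O)c(C2=NN(c3ccc(S(N)(=O)=O)cc3)C(/C=C/c3ccccc3)C2)cc1Cl` gives 47000 nM in this assay. Compound 3 `COc1ccc(C2CC(c3cc(Cl)c(C)cc3O)=NN2c2ccc(S(N)(=O)=O)cc2)cc1OC` gives 6020 nM in this assay, the lowest of the three numbers, though compound 1 sits within the scatter of it, so no order between those two can be claimed. Of the measured steps, a 7.3-fold higher number from compound 1 to compound 2 (0.86 log units; beyond the scatter) and a 7.8-fold lower number from compound 2 to compound 3 (0.89 log units; beyond the scatter) both involve the 2-phenylethenyl group and lie beyond the scatter, while a 1.1-fold lower number from compound 1 to compound 3 (0.03 log units; within the scatter) stays within it.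

Compound 4 `COc1ccc(C2CC(c3cc(Cl)c(C)cc3O)=NN2c2ccc(S(N)(=O)=O)cc2)c(OC)c1OC` differs from compound 3 by methoxy in place of hydrogen on an aromatic carbon. Going by the values given here, no measured step adds a single group to an aryl substituent; the nearest guide is a 1.1-fold lower number from compound 1 to compound 3 (0.03 log units; within the scatter), where exchanging one whole aryl group for another left the number within the scatter. A single added methoxy is a smaller change than any measured step, so for compound 4 no shift beyond the scatter is expected in this assay. The estimate for compound 4 is 6000 nM, with a range from 2500 nM to 15000 nM. This amounts to an expected step of a 1.0-fold lower number from compound 3 to compound 4 (0.00 log units; within the scatter).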

Compound 4, concentration lethal to 50% of the cells: 5560 nM
Estimate against measurement, compound 4: 1.1-fold (0.03 log units) above; measured number inside the range.
By their numbers in this assay, from the lowest: compounds 4, 3 and 1 (each within the scatter of the next); then compound 2.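

In this assay methoxy in place of hydrogen on an aromatic carbon, ortho to a large group and to a methoxy group, gives a 1.1-fold lower number from compound 3 to compound 4 (0.03 log units; within the scatter) and so leaves no readable shift at this position. The earlier steps shown here only exchanged whole groups on the saturated ring carbon, whereas this one shows that a change inside the aryl group, from 3,4-dimethoxyphenyl to 2,3,4-trimethoxyphenyl, also stays within the scatter. The exchange of 2-hydroxyphenyl for 2,3,4-trimethoxyphenyl gives a 1.2-fold lower number from compound 1 to compound 4 (0.06 log units; within the scatter) and the exchange of 2-phenylethenyl for 2,3,4-trimethoxyphenyl gives an 8.5-fold lower number from compound 2 to compound 4 (0.93 log units; beyond the scatter) so the three compounds with an aryl group on that carbon can be put in no order, while compound 2, with its 2-phenylethenyl group, alone stands apart.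

Open, as far as these compounds go, is whether a different group on this aromatic carbon, such as an amine, a carboxylic acid or a longer chain in place of methoxy, would also leave the number within the scatter. Nothing shown gives a cause for the flat result at this position or for the gap to compound 2.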